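Cytotoxicity of two glycoside ethers and a planned third

The source may report more compounds than this note shows. Statements on the series, on what has been measured and on what is new or still open speak of the compounds shown alone.

Compound 1 `CO[C@H]1O[C@H](COc2ccc(-c3ccccc3)cc2)[C@@H](O)[C@H](O)[C@H]1Oc1ccccc1`: 36000 nM
Compound 2 `CO[C@H]1O[C@H](COc2ccc(OC3CCCCC3)cc2)[C@@H](O)[C@H](O)[C@H]1Oc1ccc(C(C)C)cc1`: 27000 nM

In a functional assay on A549 cells (Homo sapiens) for cytotoxicity, read by MTT assay, with a stated time of 48 h (on this read-out lower numbers stand for an effect already at smaller amounts and higher numbers for an effect only at larger amounts of compound), compound 1 gives 36000 nM and compound 2 gives 27000 nM. Compound 2 and compound 1 lie within the scatter of each other, so neither stands apart. Compound 3 `CO[C@H]1O[C@H](COc2ccc(OC3CCCCC3)cc2)[C@@H](O)[C@H](O)[C@H]1Oc1ccc(OC2CCCCC2)cc1` differs from compound 2 in one place: cyclohexyloxy in place of isopropyl on an aromatic carbon. Within the data shown here, no step between measured compounds reaches this change, so the expected step from compound 2 to compound 3 in this assay is a 1.2-fold lower number from compound 2 to compound 3 (0.09 log units; within the scatter), a move not beyond the scatter. For compound 3 the estimate in this assay is 22000 nM, within 7000 nM to 60000 nM.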

Compound 3, half-maximal effective concentration: 18000 nM
The estimate for compound 3 lay 1.2-fold (0.09 log units) above the measured number, and the stated range covers the measured number.
By their numbers in this assay, from the lowest: compounds 3, 2 and 1 (each within the scatter of the next).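

In this assay, cyclohexyloxy in place of isopropyl on an aromatic carbon, para to a large group, gives a 1.5-fold lower number from compound 2 to compound 3 (0.18 log units; within the scatter) and so stays within the scatter. At this position, a group with a six-membered non-aromatic ring and one more hydrogen-bond acceptor therefore leaves the number of compound 2 essentially in place. No evidence on the cause of this result is available. Going by these compounds, how an amine or a carboxylic acid would read at this position remains open, as does a longer chain.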